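The compounds below may be only part of what the source reports. "The series", "measured", "known", "first", "only" and "open" are said of these compounds alone.

Measured so far in an ADME assay on SW480 cells (Homo sapiens) for cytotoxicity, read by MTT assay, with a stated time of 72 h; on this read-out lower numbers stand for stronger inhibition and higher numbers for weaker inhibition:
compound 1 `Cc1ccc(NC(=O)c2cccc(/C=C3\CC(=O)N(c4ccccc4)C3=O)c2)cc1` — > 100000 nM
compound 2 `Cc1cccc(NC(=O)c2cccc(/C=C3\CC(=O)N(c4ccccc4)C3=O)c2)c1` — > 100000 nM
compound 3 `O=C(NCc1ccccc1)c1cccc(/C=C2\CC(=O)N(c3ccccc3)C2=O)c1` — > 100000 nM

Each of these three values is a limit of the assay and not a number. Compound 1 therefore stands only at a limit, and the two other compounds stand at the same limit, so that none of the three can be placed relative to another: this is the limit of > 100000 nM in this assay, at which 3 of the 3 values shown sit. The steps between them are accordingly unreadable: a step that the two limits leave unreadable from compound 1 to compound 2, a step that the two limits leave unreadable from compound 1 to compound 3 and a step that the two limits leave unreadable from compound 2 to compound 3. All that the measured steps show is that exchanging the group on the amide-type nitrogen of the shared core, among the three variants tried, never brought the value down to a readable number.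

Compound 4 `O=C(Nc1cccc(F)c1)c1cccc(/C=C2\CC(=O)N(c3ccccc3)C2=O)c1` differs from compound 1 in the same place: 3-fluorophenyl in place of 4-methylphenyl on an amide-type nitrogen. The two steps that bear on it, from compound 1 to compound 2 and from compound 1 to compound 3, both sit at the limit, so no direction or size can be drawn from them. The only reasonable expectation is that compound 4 also stays at the limit, with an expected step that the limit leaves unreadable from compound 1 to compound 4. Compound 4 is therefore estimated at 150000 nM, within 50000 nM to 500000 nM, most likely reported as a limit again.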

Compound 4, half-maximal inhibitory concentration: > 100000 nM
Compound 4: only a limit was reported (the forecaster's own chance of this, stated with the estimate: 85%); the middle value lies beyond the limit too.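

In this assay compound 4 gives > 100000 nM, which is a limit of the assay and not a number. The steps joining compound 4 to compound 1, compound 2 and compound 3 cannot be read, and all four compounds stand together: the limit of > 100000 nM in this assay, at which 4 of the 4 values shown sit. The compounds shown leave open whether any group on the amide-type nitrogen of the shared core would give a readable value.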